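This account rests on a few compounds, and the source may have more. Where it says the series, first, only, none or still open, it means among the compounds named here.

In an ADME assay on microsomes from liver (Mus musculus) for metabolic stability, read by LC-MS, with a stated time of 10 min (on this read-out higher numbers stand for a more stable compound and lower numbers for a less stable compound), compound 1 `C[C@@H]1CN(c2cccc3c2C[C@H](CN(C)[C@H]2CCCc4cccnc42)NC3)C[C@H](C)N1`, which carries 3,5-dimethylpiperazin-1-yl, gives 85.6%. Compound 2 `CN1CCN(c2cccc3c2C[C@H](CN(C)[C@H]2CCCc4cccnc42)NC3)CC1` gives 17%, and compound 3 `CCN1CCN(c2cccc3c2C[C@H](CN(C)[C@H]2CCCc4cccnc42)NC3)CC1` gives 18.8%. Compound 3 thus stands level with compound 2 and far under compound 1. Compound 4 `CN(C[C@H]1Cc2c(cccc2N2CCNCC2)CN1)[C@H]1CCCc2cccnc21` departs from compound 3 by hydrogen in place of ethyl on an amine nitrogen in a ring, which is hydrogen in place of ethyl on an amine nitrogen in a ring. Within the data shown here, three measured steps bear on this change. Lengthening the group on that nitrogen gave a number 1.8 percentage points higher from compound 2 to compound 3 (within the scatter), so the choice between the two alkyl groups shows no effect. Leaving the dimethyl compound gave much larger steps, a number 68.6 percentage points lower from compound 1 to compound 2 (beyond the scatter) and a number 66.8 percentage points lower from compound 1 to compound 3 (beyond the scatter). Compound 1 also has hydrogen on that nitrogen, but it carries the two methyl groups as well, and the data do not separate these features. Only part of the large gap is therefore expected to be recovered. The estimated change is a number 16.2 percentage points higher from compound 3 to compound 4 (beyond the scatter), a moderate rise with wide uncertainty. Compound 4 is estimated at 35%, with an expected range from 15% to 65%.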

Compound 4, percent of the compound remaining: 19.9%
For compound 4 the middle estimate is 15.1 percentage points above the measured one, and the stated range covers the measured number.
By their numbers in this assay, from the lowest: compounds 2, 3 and 4 (each within the scatter of the next); then compound 1.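

In this assay, taking the alkyl group off the ring nitrogen changes nothing that can be read: a number 1.1 percentage points higher from compound 3 to compound 4 (within the scatter) and a number 2.9 percentage points higher from compound 2 to compound 4 (within the scatter), so hydrogen, methyl and ethyl on that amine nitrogen cannot be told apart. Hydrogen on this nitrogen was previously seen only together with the two methyl groups of compound 1, but a number 65.7 percentage points lower from compound 1 to compound 4 (beyond the scatter) now separates the two features, and the large gap stays with 3,5-dimethylpiperazin-1-yl against piperazin-1-yl. No measurement given here accounts for this gap.

The compounds shown leave open whether a single methyl group on the ring carbons of the piperazine would be enough to reach the value of compound 1. They also leave open whether an acetyl group or a longer chain on the ring nitrogen would stay level with hydrogen, methyl and ethyl.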